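The source may report more compounds than this note shows. Statements on the series, on what has been measured and on what is new or still open speak of the compounds shown alone.

Compound 1 `Cc1ccc(/C=C/C=C2\CCC=CC2=O)cc1` gives 6300 nM in a functional assay on Bel-7402 cells (Homo sapiens) for cytotoxicity, read by MTT assay, with a stated time of 72 h; a lower number here means a stronger inhibitor, a higher number a weaker inhibitor. Compound 2 `O=C1C=CCC/C1=C\C=C\c1ccc(Br)cc1` gives 3600 nM. Compound 3 `O=C1C=CCC/C1=C\C=C\c1ccc([N+](=O)[O-])cc1` gives 4200 nM.

Compound 3 stands second highest of the three numbers. Its nearest neighbour is compound 2, a 1.2-fold higher number from compound 2 to compound 3 (0.07 log units; within the scatter); its furthest is compound 1, a 1.5-fold lower number from compound 1 to compound 3 (0.18 log units; within the scatter). The remaining step, a 1.8-fold lower number from compound 1 to compound 2 (0.24 log units; within the scatter), is likewise within the scatter, so exchanging the group on the aromatic carbon has not separated these compounds in this assay.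

Compound 4 `CN(C)c1ccc(/C=C/C=C2\CCC=CC2=O)cc1` differs from compound 3 thus: dimethylamino in place of nitro on an aromatic carbon. Within the data shown here, no measured step covers this exchange; the three steps that bear on it each replace the group on the aromatic carbon and each stays within the scatter. A step within the scatter, in no set direction, is therefore expected for a 1.1-fold higher number from compound 3 to compound 4 (0.03 log units; within the scatter). Compound 4 is estimated at 4500 nM, with a range of 1500 nM to 13000 nM.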

Compound 4, half-maximal inhibitory concentration: 900 nM
Compound 4: middle estimate off by 5.0-fold (0.70 log units), on the high side; measured number outside the range, below it.
By their numbers in this assay, from the lowest: compound 4; then compounds 2, 3 and 1 (each within the scatter of the next).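

In this assay, among these compounds, dimethylamino on an aromatic carbon para to a large group gives the first exchange to go beyond the scatter (a 4.7-fold lower number from compound 3 to compound 4 (0.67 log units; beyond the scatter); a 4.0-fold lower number from compound 2 to compound 4 (0.60 log units; beyond the scatter); a 7.0-fold lower number from compound 1 to compound 4 (0.85 log units; beyond the scatter)). Methyl, bromo and nitro stayed within the scatter of one another, so this position does respond to the group placed on it, but only compound 4 shows this. Nothing at hand accounts for the step.

As far as these compounds go, whether the lower number is specific to dimethylamino or extends to a primary amine, pyrrolidine or methoxy remains open. Also open, from the compounds shown here alone, is whether dimethylamino would give the same step on another carbon of the aromatic ring.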